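The compounds below may be only part of what the source reports. "The series", "measured", "known", "first", "only" and "open" are said of these compounds alone.

Compound 2 `O=c1ccoc2cc(OCc3cn(Cc4cccc(F)c4)nn3)ccc12` carries a 3-fluorophenyl on a saturated chain carbon bound to an aromatic nitrogen. In a functional assay on SW480 cells (Homo sapiens) for cytotoxicity, read by MTT assay, with a stated time of 48 h (on this read-out lower numbers stand for stronger inhibition and higher numbers for weaker inhibition), compound 2 gives only a limit of the assay, > 100000 nM. Compound 1 `N#Cc1ccc(Cn2cc(COc3ccc4c(=O)ccoc4c3)nn2)cc1` also gives only a limit in this assay, > 100000 nM. Compound 3 `O=c1ccoc2cc(OCc3cn(Cc4cccc(Br)c4)nn3)ccc12` likewise gives only a limit, > 100000 nM. Every value shown sits at the limit of > 100000 nM in this assay, at which 3 of the 3 values shown sit, so the steps a step that the two limits leave unreadable from compound 1 to compound 2, a step that the two limits leave unreadable from compound 1 to compound 3 and a step that the two limits leave unreadable from compound 2 to compound 3 cannot be read in size or direction. Compound 4 `O=c1ccoc2cc(OCc3cn(Cc4ccccc4Cl)nn3)ccc12` differs from compound 2 by 2-chlorophenyl in place of 3-fluorophenyl on a saturated chain carbon bound to an aromatic nitrogen. Among the compounds with values here, no measured step sets a size or direction for this change. Compound 4 is therefore expected to sit near the same limit, with an estimate of 100000 nM, ranging from 30000 nM to 300000 nM. The expected step is a number no higher from compound 2 to compound 4 (the limit leaves the size open).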

Compound 4, half-maximal inhibitory concentration: 23500 nM
Estimate against measurement, compound 4: 4.3-fold (0.63 log units) above; measured number outside the range, below it.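

Within the data shown here, compound 4 gives the first real number, so the group on the saturated chain carbon bound to an aromatic nitrogen can change the result in this assay. With 2-chlorophenyl there, the steps read an at least 4.2-fold lower number from compound 2 to compound 4 (0.62 log units; beyond the scatter), an at least 4.2-fold lower number from compound 3 to compound 4 (0.62 log units; beyond the scatter) and an at least 4.2-fold lower number from compound 1 to compound 4 (0.62 log units; beyond the scatter). Each is only a minimum, and the steps among the other compounds stay unreadable: the limit of > 100000 nM in this assay, at which 3 of the 4 values shown sit.

Going by these compounds, whether the change comes from chloro itself or from its place on the ring stays open, and a 3-chlorophenyl or a 2-fluorophenyl would help separate the two. On these data alone, how a 2-methoxyphenyl would behave is also open.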